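Outlook for a piperidinylmethyl analogue in the cytotoxicity assay

The source may report more compounds than this note shows. Statements on the series, on what has been measured and on what is new or still open speak of the compounds shown alone.

Measured so far:
compound 1 `Nc1nc2ccc(C(=O)c3ccccc3)cc2n1C[C@@H]1CCCN1` – > 30000 nM
compound 2 `CC(C)(C)Cn1c(N)nc2ccc(C(=O)c3ccccc3)cc21` – > 30000 nM

Of the compounds shown here, two have been tested in an ADME assay on HL-60 cells (Homo sapiens) for cytotoxicity, read by resazurin assay, with a stated time of 72 h; a lower number here means that less compound is needed, a higher number that more compound is needed for the effect. Compound 1 `Nc1nc2ccc(C(=O)c3ccccc3)cc2n1C[C@@H]1CCCN1` gives > 30000 nM, which is a limit of the assay and not a number. Compound 2 `CC(C)(C)Cn1c(N)nc2ccc(C(=O)c3ccccc3)cc21` gives > 30000 nM in this assay, again a limit. Both values sit at the same edge of what the assay reports (the limit of > 30000 nM in this assay, at which 2 of the 2 values shown sit), so compound 2 stands at that edge with no number of its own. Among the measured compounds shown here, the only measured step, a step that the two limits leave unreadable from compound 1 to compound 2, is therefore unreadable.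

Compound 3 `Nc1nc2ccc(C(=O)c3ccccc3)cc2n1CCN1CCCCC1` differs from compound 2 by (piperidin-1-yl)methyl in place of tert-butyl on a saturated chain carbon bound to an aromatic nitrogen. For the measured compounds named here, no measured step covers this change, and the one step available gives no size. With compound 2 at a limit > 30000 nM, compound 3 is expected to end up near that limit as well, estimated at about 40000 nM within 10000 nM to 120000 nM. This estimate means an expected step that the limit leaves unreadable from compound 2 to compound 3, most likely reported again only as a limit.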

Compound 3, half-maximal effective concentration: > 30000 nM
Compound 3: only a limit was reported; the forecaster's own chance of this, stated with the estimate: 75%; the middle value does not contradict the limit.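

In this assay, among the compounds shown here, compound 1, compound 2 and compound 3 all give only a limit, so no step among them can be read. These compounds leave open whether any group on the saturated chain carbon bound to an aromatic nitrogen would give a measurable cytotoxicity value.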